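This account rests on a few compounds, and the source may have more. Where it says the series, first, only, none or still open, it means among the compounds named here.

In a functional assay on Caco-2 cells (Homo sapiens) for inhibition, read by MTT assay, with a stated time of 48 h, tested at 10 uM (on this read-out lower numbers stand for less inhibition of growth and higher numbers for more inhibition of growth at the one concentration tested), compound 1 `Cc1cc(=O)c2c(O)cc(OCc3ccc([N+](=O)[O-])cc3)c([C@H]3CCN(C)C[C@H]3O)c2o1` gives 14%, compound 2 `Cc1cc(=O)c2c(O)c(CN3CCCC3C(=O)O)c(O)c([C@H]3CCN(C)C[C@H]3O)c2o1` gives 30%, and compound 3 `CN1CC[C@H](c2c(O)cc(O)c3c(=O)cc(/C=C/c4ccc(Cl)cc4)oc23)[C@H](O)C1` gives 70%. Compound 3 therefore stands highest of the three, and its gaps to both of the others lie beyond the usual scatter of repeated measurements.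

The next compound to test is compound 4 `CN1CC[C@H](c2c(O)cc(O)c3c(=O)cc(/C=C/c4c(F)c(F)c(F)c(F)c4F)oc23)[C@H](O)C1`. It keeps the rest of compound 3 but carries 2,3,4,5,6-pentafluorophenyl in place of 4-chlorophenyl on a double-bonded chain carbon bound to a double-bonded chain carbon.

For the measured compounds named here, no measured pair here shows what a change of this kind does, so any forecast rests mainly on compound 3 at 70%. The aromatic ring stays and only its substituents differ, so a small fall in this assay is expected, probably not beyond the scatter. The estimated change is a number 8 percentage points lower from compound 3 to compound 4 (within the scatter). For compound 4, the expected value is 62%, with an estimated range from 38% to 85%.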

Compound 4, percent growth inhibition at one concentration: 59%
For compound 4 the middle estimate is 3 percentage points above the measured one, and the stated range covers the measured number.
By their numbers in this assay, from the lowest: compound 1; then compound 2; then compound 4; then compound 3.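

In this assay, for the compounds shown here, the step gives the first reading of a change in one place: a number 11 percentage points lower from compound 3 to compound 4 (beyond the scatter) when 2,3,4,5,6-pentafluorophenyl replaces 4-chlorophenyl on a double-bonded chain carbon bound to a double-bonded chain carbon. This position therefore responds to what the aromatic ring carries, but only modestly, and with this heavily fluorinated ring compound 4 still gives 59% in this assay. No measurement shown here accounts for the fall.

A plain phenyl or a 4-fluorophenyl at this place would show whether the loss follows from removing the chlorine or from adding the full set of fluorines. A 4-methoxyphenyl or a 4-aminophenyl would test whether other groups on the ring are tolerated equally well.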